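Swapping Halogens on the Benzyl Group of Compound 2

A few compounds are considered here, and "the series" means these few. Any claim that something is new, unique, unknown or untested is made for them only; others in the source may bear on it.

Among the measured compounds shown here, compound 2 `COc1ccc2[nH]c3c(c2c1)CCNC31CCN(Cc2ccc(Br)cc2F)CC1` holds the lower of the two numbers measured so far in an assay on FRT cells for positive allosteric modulation of Cystic fibrosis transmembrane conductance regulator variant N1303K (Homo sapiens), in the presence of a further agent that is not named here (on this read-out higher numbers stand for an effect only at larger amounts of compound and lower numbers for an effect already at smaller amounts), where compound 2 gives 1600 nM. For the measured compounds named here, its only measured neighbour is compound 1 `COc1ccc2[nH]c3c(c2c1)CCNC31CCN(Cc2ccccc2)CC1`, which in this assay gives 12600 nM; the step between them was a 7.9-fold lower number from compound 1 to compound 2 (0.90 log units; beyond the scatter). Compound 3 `COc1ccc2[nH]c3c(c2c1)CCNC31CCN(Cc2cc(F)c(F)cc2F)CC1` differs from compound 2 in one place: 2,4,5-trifluorophenyl in place of 4-bromo-2-fluorophenyl on a saturated chain carbon bound to an amine nitrogen in a ring. Going by the values given here, the single measured step bears only loosely on this change: it shows that a halogenated group on that saturated chain carbon gave a lower number than plain phenyl, but no measured pair compares one halogen pattern with another, so the direction of exchanging bromine for fluorine while adding a further fluorine is open. The expected step from compound 2 to compound 3 is therefore a 1.6-fold higher number from compound 2 to compound 3 (0.19 log units; within the scatter), likely within the scatter. Compound 3 is estimated at 2500 nM, with a range from 900 nM to 7000 nM.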

Compound 3, half-maximal effective concentration: 600 nM
Compound 3: the middle estimate sits 4.2-fold (0.62 log units) above what was measured; measured number outside the range, below it.
By their numbers in this assay, from the lowest: compound 3; then compound 2; then compound 1.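

In this assay, the halogen pattern on this benzyl group matters in its own right: going from 4-bromo-2-fluorobenzyl to 2,4,5-trifluorobenzyl gives a 2.7-fold lower number from compound 2 to compound 3 (0.43 log units; beyond the scatter), so the position responds to which halogens it carries, not only to whether it carries any. Bromine is not required for the lower numbers in this small set, and the fluorine-only ring, set against plain phenyl, gives a 21-fold lower number from compound 1 to compound 3 (1.32 log units; beyond the scatter), the largest step seen so far. Nothing measured here explains why this exchange lowers the number.

The change removes bromine and adds fluorine in a single step, so the contribution of each remains unseparated. On these data alone, how a ring carrying chlorine, a trifluoromethyl group or a methoxy group would compare also remains open.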